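Sulfamate for sulfate on a cyclohexanediol inositol monophosphatase ligand

The source may hold more compounds than are shown below. What is called first, only, known or untested is meant among the compounds shown, and "the series" means these compounds.

Compound 1 `CC(C)OP(=O)(O)O[C@@H]1[C@H](O)C[C@@H](O)C[C@H]1OCCCCc1ccccc1O` gives 50000 nM in an assay on isolated protein for inhibition of inositol monophosphatase 1 (Bos taurus); a lower number here means a stronger inhibitor, a higher number a weaker inhibitor. Compound 2 `O=S(=O)(O)O[C@@H]1[C@H](O)C[C@@H](O)C[C@H]1OCCCCc1ccccc1O` gives 90000 nM in this assay.

Compound 2 holds the highest of the two numbers, yet a 1.8-fold higher number from compound 1 to compound 2 (0.26 log units; within the scatter). Compound 3 `NS(=O)(=O)O[C@@H]1[C@H](O)C[C@@H](O)C[C@H]1OCCCCc1ccccc1O` carries amino in place of hydroxy on a sulfonyl sulfur. For the measured compounds named here, no measured step touches this change: the only step known swaps the whole phosphate for a sulfate, and it stayed within the scatter. With nothing pointing either way, compound 3 is expected to land near compound 2, a 1.1-fold higher number from compound 2 to compound 3 (0.05 log units; within the scatter), so compound 3 is estimated at 100000 nM with a range of 30000 nM to 300000 nM.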

Compound 3, half-maximal inhibitory concentration: > 300000 nM
Compound 3 was reported as a limit (the forecaster's own chance of this, stated with the estimate: 30%); middle value at least 3.0-fold (0.47 log units) from the limit.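

On a sulfonyl sulfur, amino in place of hydroxy gives an at least 3.3-fold higher number from compound 2 to compound 3 (0.52 log units; beyond the scatter), so this position does respond to a single-atom change, unlike the earlier swap of phosphate for sulfate, which stayed within the scatter. Set against the phosphate ester, the sulfamoyloxy group gives an at least 6.0-fold higher number from compound 1 to compound 3 (0.77 log units; beyond the scatter). Compound 3 is reported only as a limit, not as a number: the limit of > 300000 nM in this assay, at which 1 of the 3 values shown sits.

On these data alone, how far compound 3 really lies from the others stays open. So does whether a carboxylic acid or a methylsulfamoyl group on the same oxygen would match compound 1 or fall away like compound 3.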